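A few compounds are considered here, and "the series" means these few. Any claim that something is new, unique, unknown or untested is made for them only; others in the source may bear on it.

Compound 1 `CCc1nnc(SCc2ccccc2)n1N1C(=O)c2ccccc2C1=O` gives > 200000 nM in a functional assay on A549 cells (Homo sapiens) for cytotoxicity, read by MTT assay, with a stated time of 48 h; a higher number here means a weaker inhibitor, a lower number a stronger inhibitor.
Compound 2 `CCc1nnc(SCC(=O)c2ccccc2)n1N1C(=O)c2ccccc2C1=O` gives > 200000 nM in this assay.
Compound 3 `COc1cc(-c2nnc(SCc3ccccc3)n2N2C(=O)c3ccccc3C2=O)cc(OC)c1OC` gives > 200000 nM in this assay.

Each of these three values is a limit of this assay and not a number. The change from compound 1 to compound 2 is benzoyl in place of phenyl on a saturated chain carbon bound to a sulfur. Its step that the two limits leave unreadable from compound 1 to compound 2 cannot be read because compound 1 and compound 2 both sit at the limit of > 200000 nM in this assay, at which 3 of the 3 values shown sit. The cores of compound 1 and compound 3 differ by 3,4,5-trimethoxyphenyl in place of ethyl on an aromatic carbon, and the step that the two limits leave unreadable from compound 1 to compound 3 is likewise unreadable, since compound 3 also sits at the limit of > 200000 nM in this assay, at which 3 of the 3 values shown sit.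

Compound 4 `COc1cc(-c2nnc(SCC(=O)c3ccccc3)n2N2C(=O)c3ccccc3C2=O)cc(OC)c1OC` has not yet been measured in this assay. It differs from compound 3 by benzoyl in place of phenyl on a saturated chain carbon bound to a sulfur, the same change as that made from compound 1 to compound 2, at the same place on a saturated chain carbon bound to a sulfur. Since the earlier step could not be read, its size gives no guide. The expectation for compound 4 rests instead on compound 3 sitting at the limit of > 200000 nM in this assay, at which 3 of the 3 values shown sit, and on compound 2 sitting there as well. Compound 4 is therefore expected to remain at the limit, with an estimated step that the limit leaves unreadable from compound 3 to compound 4. Compound 4 is estimated at 300000 nM, between 100000 nM and 1000000 nM.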

Compound 4, half-maximal inhibitory concentration: > 200000 nM
Compound 4: only a limit was reported; the forecaster's own chance of this, stated with the estimate: 85%; the middle value does not contradict the limit.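

Compound 4 gives > 200000 nM in this assay and this value is a limit, not a number. Its steps from compound 3 and from compound 2 cannot be read, because all the compounds shown sit at the same limit: the limit of > 200000 nM in this assay, at which 4 of the 4 values shown sit.

The compounds shown leave open what size, if any, either change, benzoyl in place of phenyl or 3,4,5-trimethoxyphenyl in place of ethyl, has in this assay.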